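The compounds below may be only part of what the source reports. "The series", "measured", "known", "first", "only" and "open" are said of these compounds alone.

Compound 2, whose structure is `CCCN(CC[C@H]1CC[C@H](NC(=O)/C=C/c2cccc(F)c2)CC1)[C@H]1CCc2nc(N)sc2C1`, gives 9.9 nM in an assay on brain for displacement of a labelled ligand from D(3) dopamine receptor (Rattus norvegicus); a lower number here means a stronger inhibitor, a higher number a weaker inhibitor. Among the two compounds measured so far, compound 2 has the highest number; the nearest is compound 1, with structure `CCCN(CC[C@H]1CC[C@H](NC(=O)/C=C/c2ccc(F)cc2)CC1)[C@H]1CCc2nc(N)sc2C1`, which in this assay gives 1 nM. Among the measured compounds shown here, the one measured step, a 9.9-fold higher number from compound 1 to compound 2 (1.00 log units; beyond the scatter), came from placing 3-fluorophenyl in place of 4-fluorophenyl on a double-bonded chain carbon bound to a double-bonded chain carbon.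

Compound 3, with structure `CCCN(CC[C@H]1CC[C@H](NC(=O)/C=C/c2ccc(Cl)cc2)CC1)[C@H]1CCc2nc(N)sc2C1`, differs from compound 2 by 4-chlorophenyl in place of 3-fluorophenyl on a double-bonded chain carbon bound to a double-bonded chain carbon. This change returns the halogen to the 4-position of the phenyl ring, as in compound 1, while swapping fluorine for chlorine. Because compound 1 gives 1 nM, the number for compound 3 is expected to fall well below that of compound 2, and the expected step is a 6.6-fold lower number from compound 2 to compound 3 (0.82 log units; beyond the scatter). The estimate for compound 3 in this assay is 1.5 nM, with a range from 0.5 nM to 5 nM.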

Compound 3, inhibition constant: 2.5 nM
Beside the measured number, compound 3's estimate is 1.7-fold (0.22 log units) below it; measured number inside the range.
By their numbers in this assay, from the lowest: compound 1; then compound 3; then compound 2.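

In this assay, the change to 4-chlorophenyl gives a 4.0-fold lower number from compound 2 to compound 3 (0.60 log units; beyond the scatter), so a halogenated phenyl group other than 4-fluorophenyl can also give a lower number than 3-fluorophenyl. This step changes both the halogen and its place on the ring, but the comparison with compound 1 isolates the halogen: chloro in place of fluoro on an aromatic carbon gives a 2.5-fold higher number from compound 1 to compound 3 (0.40 log units; beyond the scatter), so even this small swap changes the number beyond the scatter. Nothing available explains why these changes alter the number.

The compounds shown leave open how plain phenyl, 4-bromophenyl or 4-methoxyphenyl would compare with 4-fluorophenyl and 4-chlorophenyl. They also leave open whether 3-chlorophenyl would give a higher number than 4-chlorophenyl, as 3-fluorophenyl does relative to 4-fluorophenyl.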